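The source may report more compounds than this note shows. Statements on the series, on what has been measured and on what is new or still open speak of the compounds shown alone.

Measured so far in an ADME assay on KB cells (Homo sapiens) for cytotoxicity, with a stated time of 48 h; a higher number here means a weaker inhibitor, a lower number a stronger inhibitor:
compound 1, `C=C1[C@H](C)CCC[C@]1(C)CC/C(C)=C/CC1=C(O)C(=O)C=C(N[C@H](C(=O)O)C(C)C)C1=O`, gives > 10 ug/mL, which is a limit of the assay and not a number.
compound 2, `CC1=CCC[C@](C)(CC/C(C)=C/CC2=C(O)C(=O)C=C(NCC(=O)O)C2=O)[C@@H]1C`, gives 5.4 ug/mL.

Within the data shown here, compound 2 supplies the only numerical reading in this assay; the other entry for the series is the limit recorded for compound 1. Among the measured compounds shown here, no step between two measured compounds can be drawn, since compound 1 and compound 2 differ in more than one place.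

Compound 3 is `CC1=CCC[C@](C)(CC/C(C)=C/CC2=C(O)C(=O)C=C(N[C@H](C(=O)O)C(C)C)C2=O)[C@@H]1C`. It differs from compound 2 by isopropyl in place of hydrogen on a saturated chain carbon bound to an amine nitrogen and a carbonyl carbon. Compound 1 carries the same (1-carboxy-2-methylpropyl)amino group on a different terpene part, and in this assay compound 1 stands at the limit of > 10 ug/mL in this assay, at which 1 of the 2 values shown sits.

On that basis the step from compound 2 to compound 3 in this assay is expected to run toward weaker inhibition, by roughly a 1.7-fold higher number from compound 2 to compound 3 (0.22 log units; within the scatter), likely beyond the scatter but resting on one comparison only. For compound 3 the expected value in this assay is 9 ug/mL, with a range from 4 ug/mL to 20 ug/mL, and a real chance that the assay again returns only a limit.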

Compound 3, half-maximal inhibitory concentration: > 10 ug/mL
Compound 3 gave a limit, no number; the forecaster's own chance of this, stated with the estimate: 45%; at least 1.1-fold (0.04 log units) between middle value and limit.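

In this assay, placing isopropyl on the saturated chain carbon bound to an amine nitrogen and a carbonyl carbon gives an at least 1.8-fold higher number from compound 2 to compound 3 (0.26 log units; that floor lies within the scatter). Compound 3 gives > 10 ug/mL, which is a limit of the assay and not a number, so this change has a floor but no measured size, and that floor does not separate the change from the scatter. This is the first comparison at this position on a single terpene part, while the comparison of the two compounds carrying (1-carboxy-2-methylpropyl)amino, which differ only in the terpene part, cannot be read, since both give limits: the limit of > 10 ug/mL in this assay, at which 2 of the 3 values shown sit.

Still open, as far as these compounds go, is whether a methyl or a benzyl group on the same saturated chain carbon would give a numerical reading in this assay, and so show how the response changes with the group at this position. Also open, from the compounds shown here alone, is how the (carboxymethyl)amino group reads on the terpene part of compound 1, a pairing that would show whether that terpene part shifts the cytotoxicity reading at all.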